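The compounds below may be only part of what the source reports. "The series", "measured", "known", "first", "only" and "open" are said of these compounds alone.

Compounds measured in a functional assay on PC-3 cells (Homo sapiens) for inhibition, read by MTT assay, with a stated time of 72 h; on this read-out higher numbers stand for weaker inhibition and lower numbers for stronger inhibition:
Compound 1 `CC(C)n1ncc2c(C(=O)Nc3ccccc3)cccc21` gives 11900 nM.
Compound 2 `CC(C)n1ncc2c(C(=O)NC3CCCC3)cccc21` gives 19400 nM.
Compound 3 `CC(C)n1ncc2c(C(=O)NCc3cn(-c4cccc(Br)c4)nn3)cccc21` gives 33700 nM.

Compound 3 carries the highest of the three numbers in this assay. Its nearest neighbour is compound 2, and the two lie within the scatter of each other; compound 1 lies furthest away, beyond the scatter, so compound 3 stands weaker than compound 1 but cannot be ordered against compound 2.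

Compound 4 `CCc1ccc(-n2cc(CNC(=O)c3cccc4c3cnn4C(C)C)nn2)cc1` has not been measured. It differs from compound 3 by 4-ethylphenyl in place of 3-bromophenyl on an aromatic nitrogen. The only measured step among these compounds is a 1.6-fold higher number from compound 1 to compound 2 (0.21 log units; within the scatter), which concerns the group on the amide-type nitrogen, not the group on the aromatic nitrogen, and it does not bear on the change at hand. For the measured compounds named here, no measured step therefore informs this one, and in the absence of such evidence no step beyond the scatter is expected in this assay.

The expected step from compound 3 to compound 4 is a 1.1-fold lower number from compound 3 to compound 4 (0.05 log units; within the scatter). Compound 4 is accordingly estimated at 30000 nM, with a range from 12000 nM to 80000 nM.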

Compound 4, half-maximal inhibitory concentration: 26600 nM
Compound 4: middle estimate off by 1.1-fold (0.05 log units), on the high side; the measured number falls inside the stated range.
By their numbers in this assay, from the lowest: compounds 1, 2, 4 and 3 (each within the scatter of the next, the first and the last beyond it).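

In this assay, for the compounds shown here, the earlier compounds offered no step at the group on the aromatic nitrogen of the five-membered ring with 3 nitrogen, and this exchange now supplies the first one: 4-ethylphenyl in place of 3-bromophenyl gives a 1.3-fold lower number from compound 3 to compound 4 (0.10 log units; within the scatter) and so stays within the scatter. At this position, then, losing the bromine and gaining the ethyl, with the heavy-atom count going from 7 to 8, does not separate the two compounds, and neither can be placed ahead of the other. Nothing measured here accounts for this result.

Still open, from the compounds shown here alone, is whether a bare phenyl, a methoxyphenyl or an aminophenyl on this nitrogen would give a step beyond the scatter. Going by these compounds, it is equally open whether a carboxylic acid or a longer alkyl chain in place of the ring would do so.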